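No Cytotoxicity Seen Yet; a Fluoro-Methoxyphenyl Analogue

The source may hold more compounds than are shown below. What is called first, only, known or untested is meant among the compounds shown, and "the series" means these compounds.

Compound 1, `CC(C)N(Cc1cccc(OCCCCCC(=O)O)c1)C(=O)c1ccc(-c2cccc(Oc3ccccc3)c2)cc1`: > 18700 nM in an ADME assay on Raji cells (Homo sapiens) for cytotoxicity, read by CellTiter-Glo and resazurin assay, with a stated time of 72 h; on this read-out higher numbers stand for an effect only at larger amounts of compound and lower numbers for an effect already at smaller amounts — a limit of the assay.
Compound 2, `CC(C)N(Cc1cccc(OCCCCCC(=O)O)c1)C(=O)c1ccc(-c2ccsc2)cc1`: > 26000 nM in this assay — a limit.
Compound 3, `CC(C)N(Cc1cccc(OCCCCCC(=O)O)c1)C(=O)c1ccc(-c2cc3ccccc3n2S(=O)(=O)c2ccccc2)cc1`: > 26000 nM in this assay — a limit.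

Of the compounds shown here, three sharing one core have been tested in this assay, and none of them gave a number; every result is a limit. For compound 2 the result, > 26000 nM, is such a limit, and the two other results are limits as well, so compound 2 cannot be placed above or below its neighbours. Of the three results, one sits at the limit of > 18700 nM in this assay, at which 1 of the 3 values shown sits, and two sit at the limit of > 26000 nM in this assay, at which 2 of the 3 values shown sit.

The next compound, compound 4, is `COc1cc(F)cc(-c2ccc(C(=O)N(Cc3cccc(OCCCCCC(=O)O)c3)C(C)C)cc2)c1`. It differs from compound 2 in one place: 3-fluoro-5-methoxyphenyl in place of thiophen-3-yl on an aromatic carbon. For the measured compounds named here, since no step between measured compounds carries a number, there is no measured step to lean on. With every result so far at a limit, the expectation for the step from compound 2 to compound 4 is none beyond the scatter, with a step that the limit leaves unreadable from compound 2 to compound 4 as the estimated change. Compound 4 is therefore expected to give about 30000 nM in this assay, within a range from 10000 nM to 100000 nM, and most likely again only as a limit.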

Compound 4, half-maximal effective concentration: > 26000 nM
Compound 4 ended at the assay's limit (the forecaster's own chance of this, stated with the estimate: 80%); the middle value lies beyond the limit too.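

Compound 2 and compound 4 both ended as limits rather than numbers, so putting 3-fluoro-5-methoxyphenyl in place of thiophen-3-yl gives no readable step in this assay. The compounds shown leave open at what concentration, if any, these compounds would reach a half-maximal effect on these cells, and whether changing this group alters that concentration.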